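Tetrazolylmethyl for Carboxy on the Amino Chain

The source may report more compounds than this note shows. Statements on the series, on what has been measured and on what is new or still open speak of the compounds shown alone.

Compound 2 `CCCCCCCOc1ccc(CC[C@](C)(N)CC(=O)O)cc1` was tested in a functional assay on CHO cells for agonist activity at sphingosine 1-phosphate receptor 2 (Homo sapiens), read by GTPgammaS binding; on this read-out higher numbers stand for weaker inhibition and lower numbers for stronger inhibition. In this assay compound 2 gives only a limit, > 22000 nM. Compound 1 `CCCCCCCOc1ccc(CC[C@](C)(N)CCS(=O)(=O)O)cc1` likewise gives only a limit in this assay, > 22000 nM. The step from compound 1 to compound 2, a step that the two limits leave unreadable from compound 1 to compound 2, is thus unreadable, both values resting at the limit of > 22000 nM in this assay, at which 2 of the 2 values shown sit. Compound 3 `CCCCCCCOc1ccc(CC[C@](C)(N)CCc2nnn[nH]2)cc1` carries (1H-tetrazol-5-yl)methyl in place of carboxy on a saturated chain carbon, two bonds along the chain from an amine nitrogen. Among the compounds with values here, no measured step bears on this change, so neither size nor direction of the step in this assay can be foreseen. The estimate for compound 3 is 30000 nM, within 8000 nM and 150000 nM. The expected step that this estimate implies is a step that the limit leaves unreadable from compound 2 to compound 3, with a further limit the likeliest outcome.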

Compound 3, half-maximal inhibitory concentration: > 22000 nM
Compound 3 ended at the assay's limit; the forecaster's own chance of this, stated with the estimate: 75%; the middle value does not contradict the limit.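

Compound 3 gives only a limit, so no step among compound 1, compound 2 and compound 3 can be read: the limit of > 22000 nM in this assay, at which 3 of the 3 values shown sit.

The compounds shown leave open how sulfomethyl, carboxy and (1H-tetrazol-5-yl)methyl rank against one another in this assay.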